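This account rests on a few compounds, and the source may have more. Where it says the series, first, only, none or still open, it means among the compounds named here.

Of the compounds shown here, three built on a shared core have been measured. In an assay on HEK-293T cells for antagonist activity at vitamin D3 receptor (Homo sapiens), read by a luciferase reporter, with a stated time of 24 h (a higher number here means a weaker inhibitor, a lower number a stronger inhibitor), compound 1 `CC(C)c1onc(-c2c(Cl)cccc2Cl)c1COc1ccc(-c2nc3cc(C(=O)O)ccc3n2C)cc1` gives 4410 nM. Compound 3 `CC(C)c1onc(-c2c(Cl)cccc2Cl)c1COc1ccc(-c2nc3ccc(C(=O)O)cc3n2-c2ccc(F)cc2)cc1` gives 2410 nM in this assay, the lower of the two recorded numbers, though its gap to compound 1 lies within the usual scatter. Compound 2 `CCCC(CCC)n1c(-c2ccc(OCc3c(-c4c(Cl)cccc4Cl)noc3C(C)C)cc2)nc2ccc(C(=O)O)cc21` reaches only > 10000 nM in this assay, which is a limit of the measurement and not a number; this is the limit of > 10000 nM in this assay, at which 1 of the 3 values shown sits.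

Going by the values given here, the one measured step that touches the group on the aromatic nitrogen is an at least 4.1-fold lower number from compound 2 to compound 3 (0.61 log units; beyond the scatter): replacing a branched alkyl chain with a flat ring brought the number down from a limit to a measured value.

Compound 4 `CC(C)c1onc(-c2c(Cl)cccc2Cl)c1COc1ccc(-c2nc3ccc(C(=O)O)cc3n2C2CCCCC2)cc1` differs from compound 3 by cyclohexyl in place of 4-fluorophenyl on an aromatic nitrogen. The flat aromatic ring of compound 3 thus gives way to a saturated ring of similar size, a change that moves back toward the kind of non-aromatic group carried by compound 2. Because compound 2 reached only (the limit of > 10000 nM in this assay, at which 1 of the 3 values shown sits), the step from compound 3 to compound 4 is expected to raise the number in this assay, with the estimated change being a 2.5-fold higher number from compound 3 to compound 4 (0.40 log units; beyond the scatter). Compound 4 is therefore expected to give about 6000 nM in this assay, somewhere between 2500 nM and 15000 nM.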

Compound 4, half-maximal inhibitory concentration: 1450 nM
Estimate against measurement, compound 4: 4.1-fold (0.62 log units) above, outside the stated range (below it).
By their numbers in this assay, from the lowest: compounds 4, 3 and 1 (each within the scatter of the next, the first and the last beyond it). At a limit, above all of these: compound 2.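

Placing cyclohexyl in place of 4-fluorophenyl on this aromatic nitrogen gives a 1.7-fold lower number from compound 3 to compound 4 (0.22 log units; within the scatter) in this assay, so the two six-membered rings cannot be told apart here, and an aromatic ring is not required at this position for a measurable value. Non-aromatic groups do not all behave alike on this nitrogen, since the open-chain 1-propylbutyl and the closed cyclohexyl ring are separated by a clear step: an at least 6.8-fold lower number from compound 2 to compound 4 (0.83 log units; beyond the scatter). Compound 2 stands at a limit of the assay and not at a number, so the true size of that step remains unknown: the limit of > 10000 nM in this assay, at which 1 of the 4 values shown sits.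

The compounds shown leave open whether closing the carbon chain into a ring is what separates cyclohexyl from 1-propylbutyl, a question that a cyclopentyl ring, a cyclopropyl ring or a short chain such as isopropyl on the same nitrogen could help to settle. They also leave open how this position would respond to a ring that carries a heteroatom, such as a piperidine with its amine or a tetrahydropyran with its ether oxygen.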